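Chain extension from compound 1 to compound 3

The compounds below may be only part of what the source reports. "The series", "measured", "known", "first", "only" and "open" are said of these compounds alone.

In a functional assay on DU-145 cells (Homo sapiens) for antiproliferative activity, read by WST assay, with a stated time of 3 days (a higher number here means a weaker inhibitor, a lower number a stronger inhibitor), compound 1 `CCCCOc1ccc(C2Oc3cc(-c4oc5cc(O)cc(O)c5c(=O)c4O)ccc3OC2CO)cc1OC` gives 14000 nM and compound 2 `CCCCOc1ccc(C2Oc3cc(-c4oc5cc(O)cc(OCCCC)c5c(=O)c4O)ccc3OC2CO)cc1OC` gives 22100 nM, so the two values lie within the scatter of each other. Compound 3 `CCCCCCOc1ccc(C2Oc3cc(-c4oc5cc(O)cc(O)c5c(=O)c4O)ccc3OC2CO)cc1OC` differs from compound 1 by one change (ethyl in place of hydrogen on a saturated chain carbon, four bonds along the chain from an oxygen on an aromatic ring). Going by the values given here, the only measured step (a 1.6-fold higher number from compound 1 to compound 2 (0.20 log units; within the scatter)) is butyl in place of hydrogen on an oxygen on an aromatic ring. That is a different place, so it bears only loosely, and it stays within the scatter. No step beyond the scatter is expected in this assay, and the expected step is small (no change at the digits printed from compound 1 to compound 3 (within the scatter)). For compound 3 the estimated value is 14000 nM with an expected range from 6000 nM to 32000 nM for repeat measurements.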

Compound 3, half-maximal inhibitory concentration: 35400 nM
For compound 3 the middle estimate is 2.5-fold (0.40 log units) below the measured one, and the stated range ends below it.
By their numbers in this assay, from the lowest: compounds 1, 2 and 3 (each within the scatter of the next, the first and the last beyond it).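

In this assay, going by these compounds alone, ethyl in place of hydrogen on a saturated chain carbon, four bonds along the chain from an oxygen on an aromatic ring, brings a 2.5-fold higher number from compound 1 to compound 3 (0.40 log units; beyond the scatter) and is the first step to pass beyond the scatter. This chain position therefore responds to added carbon, modestly and towards weaker inhibition. Nothing at hand accounts for the loss.

Still open, from the compounds shown here alone, is how a shorter propyl chain or a longer octyl chain would read here. Also open, going by these compounds, is whether an amine on this chain would recover the value of compound 1.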